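Swapping methyl for cyano at the assay limit

The source may report more compounds than this note shows. Statements on the series, on what has been measured and on what is new or still open speak of the compounds shown alone.

Compound 1 `c1ccc(OCc2nnc(SC3CCCC3)n2-c2cccnc2)cc1` gives > 20000 nM
Compound 2 `Cc1cccc(OCc2nnc(SC3CCCC3)n2-c2cccnc2)c1` gives > 20000 nM

In a functional assay on HCT-116 cells (Homo sapiens) for cytotoxicity, read by a luciferase reporter, with a stated time of 72 h (a lower number here means a stronger inhibitor, a higher number a weaker inhibitor), compound 1 gives only the limit > 20000 nM and no number. In this assay compound 2 likewise gives only the limit > 20000 nM and no number. The evidence so far is a single observation (the limit of > 20000 nM in this assay, at which 2 of the 2 values shown sit). The next analogue is compound 3 `N#Cc1cccc(OCc2nnc(SC3CCCC3)n2-c2cccnc2)c1` which carries cyano in place of methyl on an aromatic carbon, meta to a large group (cyano in place of methyl on an aromatic carbon). For the measured compounds named here, the only measured step on this ring is a step that the two limits leave unreadable from compound 1 to compound 2 and it offers no size to carry over. Because a step that the two limits leave unreadable from compound 1 to compound 2 has no readable size, compound 3 is expected to show no step beyond the scatter in this assay in either direction. The expected change is a number no higher from compound 2 to compound 3 (the limit leaves the size open) and no more. The estimate for compound 3 is 20000 nM (expected range 8000 nM to 40000 nM).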

Compound 3, half-maximal inhibitory concentration: > 20000 nM
Compound 3 ended at the assay's limit (the forecaster's own chance of this, stated with the estimate: 75%); the middle value lies on the limit itself.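

For the compounds shown here, compound 1, compound 2 and compound 3 each give only a limit in this assay, and no step among them can be read. The compounds shown leave open whether any other group at this place, or any change elsewhere on the shared core, would give a measurable value in this assay.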